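Hydroxy in place of chloro: compound 3 to compound 4

The source may hold more compounds than are shown below. What is called first, only, known or untested is meant among the compounds shown, and "the series" means these compounds.

Compound 3 `Fc1cccc(-c2nc(Nc3ccccc3Cl)c3cc(F)ccc3n2)c1` is known in a functional assay on U2OS cells (Homo sapiens) for cytotoxicity, read by MTT assay, with a stated time of 48 h (on this read-out lower numbers stand for stronger inhibition and higher numbers for weaker inhibition), only by a limit: compound 3 gives > 50000 nM, which is a limit of the assay and not a number. Compound 1 `COc1ccc(Nc2nc(-c3cccc(F)c3)nc3ccc(F)cc23)cc1` gives 32300 nM in this assay. Compound 2 `Fc1ccc(Nc2nc(-c3cccc(F)c3)nc3ccc(F)cc23)cc1` gives > 50000 nM, again a limit of the assay. Compound 3 thus stands at the limit of > 50000 nM in this assay, at which 2 of the 3 values shown sit, and nothing places it above or below compound 2.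

Compound 4 `Oc1ccccc1Nc1nc(-c2cccc(F)c2)nc2ccc(F)cc12` differs from compound 3 by hydroxy in place of chloro on an aromatic carbon. The measured steps do not touch this change: an at least 1.5-fold higher number from compound 1 to compound 2 (0.18 log units; that floor lies within the scatter) and an at least 1.5-fold higher number from compound 1 to compound 3 (0.18 log units; that floor lies within the scatter) both run into the limit, and a step that the two limits leave unreadable from compound 2 to compound 3 cannot be read at all. None of them replaces chloro with hydroxy on the phenyl bound to the nitrogen, so no direction can be drawn from them, and a value again at the limit is the most likely outcome. Compound 4 is therefore expected to give about 50000 nM in this assay, within 15000 nM to 150000 nM. The expected step from compound 3 is a number no higher from compound 3 to compound 4 (the limit leaves the size open), which would be no change beyond the scatter.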

Compound 4, half-maximal inhibitory concentration: 41400 nM
The estimate for compound 4 lay 1.2-fold (0.08 log units) above the measured number; low and high end bracket the measured number.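

In this assay, hydroxy on this aromatic carbon, ortho to a large group, gives a value that can be read as a number, where the chloro group left only a limit. The floor of that change is an at least 1.2-fold lower number from compound 3 to compound 4 (0.08 log units; that floor lies within the scatter), and the comparison with the 4-fluorophenyl group gives an at least 1.2-fold lower number from compound 2 to compound 4 (0.08 log units; that floor lies within the scatter), so neither shows a real gain for the 2-hydroxyphenyl group. Against the 4-methoxyphenyl group the result is a 1.3-fold higher number from compound 1 to compound 4 (0.11 log units; within the scatter), so these two groups cannot be told apart, and the other two values share one limit: the limit of > 50000 nM in this assay, at which 2 of the 4 values shown sit.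

Going by these compounds, how far the true values behind that limit lie from the two numbers stays open, and the steps between limits cannot be read. The compounds shown also leave open how an amine or a carboxylic acid on this carbon would read in this assay.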